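The source may report more compounds than this note shows. Statements on the series, on what has been measured and on what is new or still open speak of the compounds shown alone.

Measured so far in a functional assay (Homo sapiens) for inhibition of Nucleic Acid, tested at 100 uM; a lower number here means less inhibition, a higher number more inhibition at the concentration tested (going by the name of the read-out):
- compound 1, `OC[C@H]1OC(n2cnc3c(NCc4ccccc4)nccc32)[C@H](O)[C@@H]1O`: 32%
- compound 2, `CNc1nccc2c1ncn2C1O[C@H](CO)[C@@H](O)[C@H]1O`: 8%

Compound 2 stands lowest of the two numbers; its nearest neighbour is compound 1, and the step of a number 24 percentage points lower from compound 1 to compound 2 (beyond the scatter) is beyond the scatter and modest in size.

Compound 3, `CCCCCCNc1nccc2c1ncn2C1O[C@H](CO)[C@@H](O)[C@H]1O`, is not yet measured. The change from compound 2 is pentyl in place of hydrogen on a saturated chain carbon bound to a nitrogen on an aromatic ring; cut one bond further out it reads methylamino to hexylamino.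

Among the measured compounds shown here, only one measured step touches this position, a number 24 percentage points lower from compound 1 to compound 2 (beyond the scatter), where removing a phenyl from the same saturated chain carbon lowered inhibition. Compound 3 reverses the direction of growth at that carbon, but with pentyl rather than phenyl, so the size of the earlier step is only a rough guide. An increase in this assay is therefore expected for compound 3, likely smaller than the earlier drop, and a change within the scatter cannot be excluded; the expected step is a number 12 percentage points higher from compound 2 to compound 3 (beyond the scatter).

Compound 3 is estimated at 20%, with a range from 0% to 45%.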

Compound 3, a percentage reported as inhibition, at one concentration (the size of the read-out at that concentration, not a potency): 8%
Compound 3: middle estimate off by 12 percentage points, on the high side, and the stated range covers the measured number.
By their numbers in this assay, from the lowest: compounds 2 and 3 (each within the scatter of the next); then compound 1.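

In this assay, going from methylamino to hexylamino, with pentyl in place of hydrogen on a saturated chain carbon bound to a nitrogen on an aromatic ring, gives no change at the digits printed from compound 2 to compound 3 (within the scatter), so a longer saturated chain at this position does not bring back the inhibition seen with phenyl. Pentyl in place of phenyl gives a number 24 percentage points lower from compound 1 to compound 3 (beyond the scatter), a step of the same printed size as a number 24 percentage points lower from compound 1 to compound 2 (beyond the scatter), so among these three compounds the higher number belongs only to the phenyl-bearing compound 1, and growth at this carbon does not by itself raise the number. Nothing measured here gives a reason for either step.

Still open, from the compounds shown here alone, is whether the phenyl ring itself carries the higher number, which a cyclohexyl group on the same carbon or a phenyl ring bearing a methoxy group would test. Also open, going by these compounds, is whether a chain longer than hexyl, or a chain ending in an amine or a carboxylic acid, would separate from compound 2 and compound 3 in this assay.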